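Variation of the ring substituent in a sulfonamide amide series

A few compounds are considered here, and "the series" means these few. Any claim that something is new, unique, unknown or untested is made for them only; others in the source may bear on it.

Compound 2 `CC(C)COc1cc(C(F)(F)F)ccc1CNC(=O)C(C)c1ccc(NS(C)(=O)=O)c(F)c1` in an assay on CHO cells for antagonist activity at transient receptor potential cation channel subfamily V member 1 (Homo sapiens), read by FLIPR (on this read-out higher numbers stand for weaker inhibition and lower numbers for stronger inhibition), gives 0.8 nM. Among the compounds with values here, compound 1 `CC(C(=O)NCc1ccc(C(F)(F)F)cc1N1CCC(C(F)(F)F)CC1)c1ccc(NS(C)(=O)=O)c(F)c1` gives 0.4 nM in this assay, and the only measured step, a 2.0-fold higher number from compound 1 to compound 2 (0.30 log units; within the scatter), places the two compounds within the scatter of each other, so no order between them is claimed. Compound 3 `CC(C(=O)NCc1ccc(C(F)(F)F)cc1SCCCO)c1ccc(NS(C)(=O)=O)c(F)c1` is not yet measured; it differs from compound 2 by (3-hydroxypropyl)sulfanyl in place of isobutoxy on an aromatic carbon. Within the data shown here, the one step that bears on this position, a 2.0-fold higher number from compound 1 to compound 2 (0.30 log units; within the scatter), is within the scatter, which suggests the position accepts rather different groups without a large change in this assay. Beyond that single step there is nothing to lean on, and the entering (3-hydroxypropyl)sulfanyl group is unlike either of the measured groups. The expectation is therefore a step of modest size, a 2.5-fold higher number from compound 2 to compound 3 (0.40 log units; beyond the scatter), for compound 3. For compound 3 the estimate in this assay is 2 nM, with a range from 0.5 nM to 10 nM.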

Compound 3, inhibition constant: "not active" (no number reported)
Compound 3 has no reported number here, so the estimate cannot be set against anything.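

Within the data shown here, compound 3 is recorded only as "not active" in this assay, without a number, so no step from compound 2 to compound 3 can be read. No evidence bears on this result. The compounds shown leave open how far (3-hydroxypropyl)sulfanyl in place of isobutoxy moves the number.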